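This account rests on a few compounds, and the source may have more. Where it says the series, first, only, none or still open, it means among the compounds named here.

Within the data shown here, compound 3 `O=C1N=C(N2CCC[C@H]2C(=O)Nc2ccc3ncnc(Nc4cccc(Cl)c4)c3c2)S/C1=C/c1cccnc1` stands lowest of the three numbers so far in a functional assay on HepG2 cells (Homo sapiens) for antiproliferative activity, read by MTT assay (on this read-out lower numbers stand for stronger inhibition and higher numbers for weaker inhibition), with 8500 nM. Compound 1 `COc1ccc(/C=C2/SC(N3CCC[C@H]3C(=O)Nc3ccc4ncnc(Nc5cccc(Cl)c5)c4c3)=NC2=O)cc1` gives 19000 nM and compound 2 `O=C1N=C(N2CCC[C@H]2C(=O)Nc2ccc3ncnc(Nc4cccc(Cl)c4)c3c2)S/C1=C/c1ccccc1Cl` gives 28100 nM. The steps of a 2.2-fold lower number from compound 1 to compound 3 (0.35 log units; beyond the scatter) and a 3.3-fold lower number from compound 2 to compound 3 (0.52 log units; beyond the scatter) were beyond the scatter, while a 1.5-fold higher number from compound 1 to compound 2 (0.17 log units; within the scatter) was not. Compound 4 `O=C1N=C(N2CCC[C@H]2C(=O)Nc2ccc3ncnc(Nc4cccc(Cl)c4)c3c2)S/C1=C/c1ccc(-c2ccccc2)cc1` differs from compound 3 by 4-phenylphenyl in place of pyridin-3-yl on a double-bonded chain carbon bound to a double-bonded ring carbon. The two steps into compound 3 bear on this change: both carbon-only aryls gave higher numbers than pyridin-3-yl, so a return to a carbon-only aryl, here a larger one with no acceptor, is expected to raise the number by about the same modest size, a 2.4-fold higher number from compound 3 to compound 4 (0.37 log units; beyond the scatter). For compound 4 the expected value in this assay is 20000 nM, ranging from 7000 nM to 60000 nM.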

Compound 4, half-maximal inhibitory concentration: 15400 nM
For compound 4 the middle estimate is 1.3-fold (0.11 log units) above the measured one; the range from low to high includes it.
By their numbers in this assay, from the lowest: compounds 3, 4, 1 and 2 (each within the scatter of the next, the first and the last beyond it).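

Among these compounds, at this place, on a double-bonded chain carbon bound to a double-bonded ring carbon, 4-phenylphenyl is the first group whose steps to all three earlier compounds stay within the scatter (a 1.8-fold higher number from compound 3 to compound 4 (0.26 log units; within the scatter); a 1.8-fold lower number from compound 2 to compound 4 (0.26 log units; within the scatter); a 1.2-fold lower number from compound 1 to compound 4 (0.09 log units; within the scatter)). Compounds 1, 2 and 3 each carry one aromatic ring here, so the position now also accommodates two six-membered aromatic rings of carbon only, with no step beyond the scatter. No evidence is at hand that explains this result. From the compounds shown here alone, it remains open whether an amine or a carboxylic acid on the aryl ring would move the number beyond the scatter. Going by these compounds, a saturated ring such as piperidine in place of the aryl ring is equally open.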